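Swapping the Five-Membered Ring on the Amide Carbonyl

The source may report more compounds than this note shows. Statements on the series, on what has been measured and on what is new or still open speak of the compounds shown alone.

Measured so far:
compound 1, `COc1cc2nccc(Oc3ccc(NC(=O)c4ncc(-c5ccc(F)cc5)o4)cc3)c2cc1OC`: > 100000 nM, a limit of the assay
compound 2, `COc1cc2nccc(Oc3ccc(NC(=O)c4nnc(-c5ccc(F)cc5)o4)cc3)c2cc1OC`: 52300 nM

Both share one core and were tested in a functional assay on HT-29 cells (Homo sapiens) for antiproliferative activity, read by MTT assay, with a stated time of 72 h; on this read-out higher numbers stand for weaker inhibition and lower numbers for stronger inhibition. Compound 1 sits at the assay's limit, (the limit of > 100000 nM in this assay, at which 1 of the 2 values shown sits). Among the compounds with values here, compound 2 supplies the only real number, and the step of an at least 1.9-fold lower number from compound 1 to compound 2 (0.28 log units; that floor lies within the scatter) has a floor inside the scatter, so it shows no clear change. The untested compound 3, `COc1cc2nccc(Oc3ccc(NC(=O)c4cc(-c5ccc(F)cc5)on4)cc3)c2cc1OC`, differs from compound 2 in that (5-(4-fluorophenyl)-1,2-oxazol-3-yl in place of 5-(4-fluorophenyl)-1,3,4-oxadiazol-2-yl on a carbonyl carbon). Within the data shown here, only that one step bears on this change, and it resolves nothing, so no step beyond the scatter is expected: a 1.1-fold higher number from compound 2 to compound 3 (0.06 log units; within the scatter). Compound 3 is therefore estimated at 60000 nM, between 20000 nM and 150000 nM.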

Compound 3, half-maximal inhibitory concentration: > 100000 nM
Compound 3 ended at the assay's limit; the forecaster's own chance of this, stated with the estimate: 35%; at least 1.6-fold (0.22 log units) between middle value and limit.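

Placing 5-(4-fluorophenyl)-1,2-oxazol-3-yl on the carbonyl carbon in place of 5-(4-fluorophenyl)-1,3,4-oxadiazol-2-yl gives, in this assay, an at least 1.9-fold higher number from compound 2 to compound 3 (0.28 log units; that floor lies within the scatter) as the step, so this change also shows no clear effect. The step between compound 1 and compound 3 cannot be read, as both values are limits. Within the data shown here, compound 2 at 52300 nM remains the only real number for this position. The other two compounds share one limit: the limit of > 100000 nM in this assay, at which 2 of the 3 values shown sit.

On these data alone, how far compound 1 and compound 3 lie past that limit stays open. So does how a simple amine or a carboxylic acid on this carbonyl carbon would read.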